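Methyl in place of fluoro on the aryl ring

The compounds below may be only part of what the source reports. "The series", "measured", "known", "first", "only" and "open" are said of these compounds alone.

Going by the values given here, in a functional assay on NCI-H460 cells (Homo sapiens) for cytotoxicity, read by MTT assay, with a stated time of 72 h (a lower number here means a stronger inhibitor, a higher number a weaker inhibitor), compound 3 `COc1cc2c(Oc3ccc(NC(=O)c4cn(-c5ccccc5F)nn4)cc3F)ccnc2cc1OCCCN1CCN(C)CC1` gives 230 nM, the lowest of the three numbers measured so far. Compound 1 `COc1cc2c(Oc3ccc(NC(=O)c4cn(-c5ccccc5C)nn4)cc3F)ccnc2cc1OCCCN1CCCC1` gives 1260 nM and compound 2 `COc1cc2c(Oc3ccc(NC(=O)c4cn(-c5ccccc5C)nn4)cc3F)ccnc2cc1OCCCN1CCCCC1` gives 2100 nM; the step of a 1.7-fold higher number from compound 1 to compound 2 (0.22 log units; within the scatter) lies within the scatter and concerns a different part of the molecule. Compound 4 `COc1cc2c(Oc3ccc(NC(=O)c4cn(-c5ccccc5C)nn4)cc3F)ccnc2cc1OCCCN1CCN(C)CC1` differs from compound 3 by methyl in place of fluoro on an aromatic carbon. Among the compounds with values here, no measured step bears directly on this change: compound 1 carries the same methylphenyl group, but it differs from compound 3 in a second place as well, so its gap to compound 3 mixes two changes. The step of a 2.0-fold higher number from compound 3 to compound 4 (0.29 log units; within the scatter) is therefore expected to be modest, with a weaker outcome somewhat more likely than a stronger one. Compound 4 is estimated at 450 nM, between 150 nM and 1400 nM.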

Compound 4, half-maximal inhibitory concentration: 3650 nM
Estimate against measurement, compound 4: 8.1-fold (0.91 log units) below; measured number outside the range, above it.
By their numbers in this assay, from the lowest: compound 3; then compounds 1, 2 and 4 (each within the scatter of the next, the first and the last beyond it).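

In this assay, methyl in place of fluoro on this aromatic carbon gives the largest step seen so far, a 16-fold higher number from compound 3 to compound 4 (1.20 log units; beyond the scatter), so a swap of one small group on this ring can matter a great deal. With methyl kept, changing the group at the end of the chain matters far less: the step is a 1.7-fold higher number from compound 2 to compound 4 (0.24 log units; within the scatter), and the other is a 2.9-fold higher number from compound 1 to compound 4 (0.46 log units; beyond the scatter). Nothing measured here explains the size of the fluoro-to-methyl step.

As far as these compounds go, whether fluoro would give a similar gain with pyrrolidin-1-yl or piperidin-1-yl at the chain end remains open. So does how chloro, methoxy or a plain hydrogen would compare at this position.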